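Phenylsulfanyl in Place of Phenoxy on a Weak Inhibitor

The source may report more compounds than this note shows. Statements on the series, on what has been measured and on what is new or still open speak of the compounds shown alone.

Measured so far:
- compound 1 `CC(CCc1ccc(-c2ccccc2)cc1)CC(=O)O`: 80000 nM
- compound 2 `CC(CC(=O)O)CC(=O)c1ccc(Oc2ccccc2)cc1`: 2100000 nM

Both compounds were tested in an assay (strain CD) for inhibition of 3-hydroxy-3-methylglutaryl-coenzyme A reductase (Rattus norvegicus), read by scintillation counting, using microsomes, with a stated time of 90 min; a higher number here means a weaker inhibitor, a lower number a stronger inhibitor. Compound 1 gives 80000 nM and compound 2 gives 2100000 nM in this assay. Compound 2 therefore stands at the higher of the two numbers, and its gap to compound 1 is stated as lying beyond the usual scatter, so compound 2 is the weaker inhibitor of the two measured here.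

Compound 3 `CC(CC(=O)O)CC(=O)c1ccc(Sc2ccccc2)cc1` has not been measured. It differs from compound 2 in one place: phenylsulfanyl in place of phenoxy on an aromatic carbon. Going by the values given here, no measured pair shows what such a swap does in this assay, so the expectation rests only on the closeness of the two structures. Because compound 2 gives 2100000 nM, compound 3 is expected to land near that figure. The expected step from compound 2 to compound 3 is a 1.4-fold lower number from compound 2 to compound 3 (0.15 log units; within the scatter), likely within the scatter in either direction. Compound 3 is estimated at 1500000 nM, with a range from 400000 nM to 6000000 nM.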

Compound 3, half-maximal inhibitory concentration: 780000 nM
Estimate against measurement, compound 3: 1.9-fold (0.28 log units) above; the range from low to high includes it.
By their numbers in this assay, from the lowest: compound 1; then compound 3; then compound 2.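

Going by these compounds alone, as the first measured swap at this position, on an aromatic carbon para to a group of 9 heavy atoms, phenylsulfanyl in place of phenoxy gives a modest change that still lies beyond the scatter in this assay (a 2.7-fold lower number from compound 2 to compound 3 (0.43 log units; beyond the scatter)). The two groups have the same count of heavy atoms and differ by sulfur against oxygen, so this position responds to a change of a single atom, although compound 3 still gives 780000 nM. Nothing at hand explains why the number moves this way.

From the compounds shown here alone, whether the position would respond further to a phenylamino or benzyl group, which place nitrogen or carbon at that atom, stays open. So does whether the same swap would give a similar step on a different core.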